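The compounds below may be only part of what the source reports. "The series", "measured", "known", "first", "only" and "open" are said of these compounds alone.

Compounds measured in an assay on CHO cells, read by calcium flux; a lower number here means a stronger inhibitor, a higher number a weaker inhibitor:
compound 1, `CC(C)(C)c1ccc(NC(=O)c2csc(Cc3c(Cl)cccc3Cl)n2)cc1`, gives 570 nM;
compound 2, `CCc1ccc(NC(=O)c2csc(Cc3c(Cl)cccc3Cl)n2)cc1`, gives 810 nM;
compound 3, `COc1ccc(NC(=O)c2csc(Cc3c(Cl)cccc3Cl)n2)cc1`, reaches only the limit of this assay, > 4000 nM.

Within the data shown here, compound 3 therefore stands at the weak end of the three: its result is a limit, not a number, and it shares the upper boundary noted as the limit of > 4000 nM in this assay, at which 1 of the 3 values shown sits, with no other compound. The two steps leading to it, an at least 7.0-fold higher number from compound 1 to compound 3 (0.84 log units; beyond the scatter) and an at least 4.9-fold higher number from compound 2 to compound 3 (0.69 log units; beyond the scatter), are both beyond the scatter, while a 1.4-fold higher number from compound 1 to compound 2 (0.15 log units; within the scatter) is not.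

Compound 4, `O=C(Nc1ccc(Br)cc1)c1csc(Cc2c(Cl)cccc2Cl)n1`, has not yet been measured. It differs from compound 3 as follows: bromo in place of methoxy on an aromatic carbon. Both measured steps into compound 3 replaced an alkyl group with methoxy and raised the number at least modestly; the change to compound 4 removes the methoxy again, in favor of bromo. The reasonable expectation is a step back toward the numbers of compound 1 and compound 2, that is, a lower number in this assay, of size an at least 3.3-fold lower number from compound 3 to compound 4 (0.52 log units; beyond the scatter). Compound 4 is accordingly estimated at 1200 nM, within a range from 400 nM to 4000 nM.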

Compound 4, half-maximal inhibitory concentration: 400 nM
For compound 4 the middle estimate is 3.0-fold (0.48 log units) above the measured one; measured number inside the range.
By their numbers in this assay, from the lowest: compounds 4, 1 and 2 (each within the scatter of the next, the first and the last beyond it). At a limit, above all of these: compound 3.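

In this assay, among these compounds, the earlier compounds showed low numbers at this position only with alkyl groups; bromo, a single bromine atom, now also gives a low number, with a 1.4-fold lower number from compound 1 to compound 4 (0.15 log units; within the scatter) and a 2.0-fold lower number from compound 2 to compound 4 (0.31 log units; beyond the scatter). Of the four groups shown on this aromatic carbon, methoxy alone stands apart, and the change from it to bromo gives an at least 10-fold lower number from compound 3 to compound 4 (1.00 log units; beyond the scatter). Compound 3 gives only a limit, so the true size of that step cannot be read and the printed size is a minimum: the limit of > 4000 nM in this assay, at which 1 of the 4 values shown sits.

The compounds shown leave open whether fluoro, chloro or iodo would behave as bromo does here. They also leave open how an amine, a hydroxyl or a longer alkoxy chain would read at this position.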